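Shifting a Hydroxyl Group: One Change in Two Settings

A few compounds are considered here, and "the series" means these few. Any claim that something is new, unique, unknown or untested is made for them only; others in the source may bear on it.

Compound 1 `Oc1cccc(-c2cc(-c3ccccc3C(F)(F)F)cc(-c3cccc(O)c3)n2)c1` and compound 2 `Oc1ccc(-c2cc(-c3ccccc3C(F)(F)F)cc(-c3cccc(O)c3)n2)cc1` are built on the same core and differ in a single place: compound 2 carries 4-hydroxyphenyl in place of 3-hydroxyphenyl on an aromatic carbon. In a functional assay on T47D cells (Homo sapiens) for inhibition (a lower number here means a stronger inhibitor, a higher number a weaker inhibitor), compound 1 gives 4350 nM, while compound 2 gives 3210 nM; the result is a 1.4-fold lower number from compound 1 to compound 2 (0.13 log units; within the scatter), so the two compounds cannot be told apart on this measurement.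

Compound 3 `Oc1ccc(-c2cc(-c3ccc(OC(F)(F)F)cc3)cc(-c3cccc(O)c3)n2)cc1` rests on a different core, and the difference between the two cores is not broken down here. In this assay compound 3 gives 18900 nM, the highest of the three numbers and beyond the scatter from both compound 1 and compound 2.

Compound 4 `Oc1ccc(-c2cc(-c3ccc(OC(F)(F)F)cc3)cc(-c3ccc(O)cc3)n2)cc1`, not yet measured, differs from compound 3 by 4-hydroxyphenyl in place of 3-hydroxyphenyl on an aromatic carbon. This is the same kind of change that separates compound 1 from compound 2, but the surroundings differ: in compound 1 the place is meta to a 2-(trifluoromethyl)phenyl group and meta to a 3-hydroxyphenyl group, whereas in compound 3 it is meta to a 4-hydroxyphenyl group and meta to a large group. Because the step seen as a 1.4-fold lower number from compound 1 to compound 2 (0.13 log units; within the scatter) was small, a similarly small step is expected here, a 1.4-fold lower number from compound 3 to compound 4 (0.13 log units; within the scatter). Compound 4 is therefore estimated at 14000 nM in this assay, with the expected range running from 5000 nM to 40000 nM.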

Compound 4, half-maximal inhibitory concentration: 5150 nM
The estimate for compound 4 lay 2.7-fold (0.43 log units) above the measured number, and the stated range covers the measured number.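

The same swap of 3-hydroxyphenyl for 4-hydroxyphenyl, at the same place on the central ring, gives a 3.7-fold lower number from compound 3 to compound 4 (0.56 log units; beyond the scatter) in this assay, so on the core of compound 3 it produces a real difference, which it did not do on the core of compound 1. Set side by side, the two steps do not match in size, so the result of this change on one core cannot simply be copied to the other: the same change on two cores in this assay, a 1.4-fold lower number (0.13 log units; within the scatter) from compound 1 to compound 2 and a 3.7-fold lower number (0.56 log units; beyond the scatter) from compound 3 to compound 4, 2.7-fold (0.43 log units) apart, beyond the scatter of two such steps. Within the data shown here, this comparison rests on only one pair of compounds per core, so it shows that the size of the step varied between these two cores, but not why it varied, which part of the core is responsible, or what the step would be on a third core.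

Every compound shown carries hydroxyl groups on its outer phenyl rings, so it remains open what an amine, a methoxy group or a carboxylic acid would do in their place on either core. Also open, as far as these compounds go, is whether the larger step on the core of compound 3 would persist if the group carrying the trifluoromethoxy were replaced by a plain phenyl ring.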